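A few compounds are considered here, and "the series" means these few. Any claim that something is new, unique, unknown or untested is made for them only; others in the source may bear on it.

Measured compounds:
- compound 1, `C[C@@H](NC(=O)Nc1ccc(F)cc1F)c1ccccc1`: 100%
- compound 2, `C[C@H](NC(=O)Nc1ccc(F)cc1F)c1ccccc1`: 101%
- compound 3, `Cc1ccc(NC(=O)N[C@@H](C)c2ccccc2)c(F)c1`: 100%

All three were run in an ADME assay on the whole organism with Oryza sativa as the target, tested at 0.1 uM; on this read-out higher numbers stand for a weaker effect at the one concentration tested and lower numbers for a stronger effect. Compound 1 gives 100% there, compound 2 gives 101% and compound 3 gives 100%; the three numbers sit together within the scatter, so no order among them is read.

Compound 1 and compound 2 share all atoms and bonds and (the two compounds have the same atoms and bonds and differ only in configuration as drawn: 1 of 1 stereo elements differ; a stereocentre at a saturated chain carbon is drawn S in compound 2 and R in compound 1). The step of a number 1 percentage points higher from compound 1 to compound 2 (within the scatter) is small, and the only difference between the two is the fact that compounds 1 and 2 differ only in the configuration as drawn.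

From compound 2 to compound 3 the change is methyl in place of fluoro on an aromatic carbon, placed meta to a fluoro group and para to a large group. This gives a number 1 percentage points lower from compound 2 to compound 3 (within the scatter).

Compound 4, `Cc1cc(F)ccc1NC(=O)N[C@H](C)c1ccccc1`, is not yet measured. It stands to compound 1 as compound 3 stands to compound 2: the change is methyl in place of fluoro on an aromatic carbon. The surroundings of the place are not the same, however: in compound 4 the methyl sits ortho to a large group and meta to a fluoro group, whereas in compound 3 it sits meta to a fluoro group and para to a large group. It is therefore the same kind of change, not the same change.

For compound 4 the step from compound 1 is expected to be about no change at the digits printed from compound 1 to compound 4 (within the scatter), resting on the measured step of a number 1 percentage points lower from compound 2 to compound 3 (within the scatter) for the same kind of change. In this assay compound 4 is thus estimated at 100%, with a range from 90% to 110%.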

Compound 4, a percentage reported as activity, at one concentration (the size of the read-out at that concentration, not a potency): 100%
Compound 4: the middle estimate sits on the measured number at the digits printed; low and high end bracket the measured number.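

In this assay, methyl in place of fluoro on an aromatic carbon gives no change at the digits printed from compound 1 to compound 4 (within the scatter), and the step reads the same as the earlier one on the other core: the same change on two cores in this assay, a number 1 percentage points lower (within the scatter) from compound 2 to compound 3 and no change at the digits printed (within the scatter) from compound 1 to compound 4, 1 percentage points apart, within the scatter of two such steps. Within this small set, the change therefore carries from one core to the other without a visible difference in this read-out, even though the place in compound 4, ortho to a large group and meta to a fluoro group, is not the place of the earlier step. This does not show that the change is neutral in general: the evidence is a pair of steps at one concentration, which gives the size of the read-out and not a potency, and core and place vary together across the pair, so their separate contributions cannot be told apart.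

Because all the numbers shown lie so close together, the notes leave open whether any substituent on this ring can move the read-out at all. An amine or a carboxylic acid on the aromatic ring, or a longer chain in place of the methyl on the saturated chain carbon, would be needed to test whether this flat picture extends beyond fluoro and methyl.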